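The source may hold more compounds than are shown below. What is called first, only, known or untested is meant among the compounds shown, and "the series" means these compounds.

Compound 3, `COc1ccc(OC)c(C2OC(c3cc(OC)c(OC)c(OC)c3)=NN2C(C)=O)c1`, stands highest of the three compounds measured in a functional assay on PC-3 cells (Homo sapiens) for antiproliferative activity, read by MTT assay, tested at 1 uM (a higher number here means a stronger effect of the compound at the concentration tested, a lower number a weaker effect), where compound 3 gives 37.2%. Its nearest neighbour is compound 2, `COc1cc(C2=NN(C(C)=O)C(c3ccccc3F)O2)cc(OC)c1OC`, which in this assay gives 13.5%, and furthest away is compound 1, `COc1cc(C2=NN(C(C)=O)C(c3ccc(F)cc3)O2)cc(OC)c1OC`, which in this assay gives 0%. The three steps all concern the aryl group on the saturated ring carbon: a number 13.5 percentage points higher from compound 1 to compound 2 (beyond the scatter), a number 37.2 percentage points higher from compound 1 to compound 3 (beyond the scatter) and a number 23.7 percentage points higher from compound 2 to compound 3 (beyond the scatter). Both steps that reach compound 3 go upward, so the 2,5-dimethoxyphenyl is the group linked to the highest number, while the two fluorophenyl groups sit lower.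

Compound 4, `COc1cc(C2=NN(C(C)=O)C(c3cccc(C(F)(F)F)c3)O2)cc(OC)c1OC`, carries the change (3-(trifluoromethyl)phenyl in place of 2,5-dimethoxyphenyl on a saturated ring carbon). Within the data shown here, the steps that bear on it are the two that lead into compound 3, a number 37.2 percentage points higher from compound 1 to compound 3 (beyond the scatter) and a number 23.7 percentage points higher from compound 2 to compound 3 (beyond the scatter), both of which show that replacing the 2,5-dimethoxyphenyl by a fluorine-bearing phenyl lowers the number well beyond the scatter. Compound 4 also carries a fluorine-bearing phenyl without hydrogen-bond acceptors, so for compound 4 a downward step of about a number 22.2 percentage points lower from compound 3 to compound 4 (beyond the scatter) is expected in this assay. Compound 4 is therefore estimated to give 15%, with a range from 0% to 35%.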

Compound 4, a percentage reported as inhibition, at one concentration (the size of the read-out at that concentration, not a potency): 30.1%
Beside the measured number, compound 4's estimate is 15.1 percentage points below it, within the range that was stated.
By their numbers in this assay, from the lowest: compound 1; then compound 2; then compounds 4 and 3 (each within the scatter of the next).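

In this assay the 3-(trifluoromethyl)phenyl group gives a step that reads a number 7.1 percentage points lower from compound 3 to compound 4 (within the scatter), so exchanging the 2,5-dimethoxyphenyl for this group, with 0 hydrogen-bond acceptors in place of 2, leaves the read-out within the scatter. Compound 4 therefore goes against the link between a fluorine-bearing phenyl and a low number that compounds 1 and 2 suggested, since the steps are a number 16.6 percentage points higher from compound 2 to compound 4 (beyond the scatter) and a number 30.1 percentage points higher from compound 1 to compound 4 (beyond the scatter), and so at this position the fluorine-bearing groups span a wide part of the measured range and hydrogen-bond acceptors on the phenyl ring are not needed to reach the upper part of it. No measurement available here accounts for these differences.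

The three fluorine-bearing groups differ both in the substituent and in where it sits on the phenyl ring, so the two influences cannot be separated, and a 2-(trifluoromethyl)phenyl or 4-(trifluoromethyl)phenyl group would be needed to tell them apart. On these data alone, how an unsubstituted phenyl, a pyridine ring or a phenyl ring bearing an amine or a carboxylic acid would behave at this saturated ring carbon remains open, as does the effect of all these compounds at any other concentration, which a read-out at one concentration does not give.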